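This account rests on a few compounds, and the source may have more. Where it says the series, first, only, none or still open, it means among the compounds named here.

Compound 1 `CCCCCc1cc(O)cc(O)c1Oc1cc2c(cc1OC)C(O)(CCCC)OC2=O` and compound 2 `CCCCCc1c(Oc2cc3c(cc2OC)C(CCCC)(OC)OC3=O)c(O)cc(O)c1C(=O)O` were both examined in an ADME assay on U-937 cells (Homo sapiens) for cytotoxicity, read by MTT assay, with a stated time of 24 h, tested at 10 uM; a higher number here means a weaker effect of the compound at the concentration tested, a lower number a stronger effect. In this assay compound 1 gives 118%, and compound 2 gives 126%. Of these two numbers compound 2 holds the larger, yet the gap to compound 1 lies within the scatter. Compound 3 `CCCCCc1cc(O)cc(O)c1Oc1cc2c(cc1OC)C(CCCC)(OC)OC2=O` has not been measured. It differs from compound 2 in one place: hydrogen in place of carboxy on an aromatic carbon. Among the measured compounds shown here, no step between measured compounds that differ in one place is at hand. The step in this assay is expected to be a number 11 percentage points lower from compound 2 to compound 3 (beyond the scatter), nothing beyond the scatter. Compound 3 is estimated to give 115%, between 95% and 135%.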

Compound 3, a percentage reported as activity, at one concentration (the size of the read-out at that concentration, not a potency): 116%
Compound 3: middle estimate off by 1 percentage points, on the low side, and the stated range covers the measured number.
By their numbers in this assay, from the lowest: compounds 3, 1 and 2 (each within the scatter of the next).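

In this assay, hydrogen in place of carboxy on this aromatic carbon, ortho to a pentyl group, gives a number 10 percentage points lower from compound 2 to compound 3 (within the scatter) and so leaves the read-out unchanged within the scatter at this position. Methyl in place of hydrogen on the oxygen on a saturated carbon gives a number 2 percentage points lower from compound 1 to compound 3 (within the scatter) and likewise separates nothing. No other data at hand bear on either result.

The compounds shown leave open whether an amine or a methyl ester on this aromatic carbon, or an ethyl group on that oxygen, would give a step beyond the scatter.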